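The source may hold more compounds than are shown below. What is called first, only, known or untested is meant among the compounds shown, and "the series" means these compounds.

Measured so far in a functional assay on MCF7 cells (Homo sapiens) for antiproliferative activity, read by MTT assay, with a stated time of 48 h, in the presence of a further agent that is not named here; on this read-out higher numbers stand for weaker inhibition of growth and lower numbers for stronger inhibition of growth:
- compound 1 `Cc1ccc(-c2nn(-c3ccccc3)cc2C(=O)NOCc2ccccc2Cl)cc1` gives 2640 nM
- compound 2 `Cc1ccc(-c2nn(-c3ccccc3)cc2C(=O)NOCc2ccc(Cl)cc2Cl)cc1` gives 2310 nM

For the measured compounds named here, compound 1 holds the highest of the two numbers in this assay, but its only neighbour sits within the scatter: the step of a 1.1-fold lower number from compound 1 to compound 2 (0.06 log units; within the scatter) brings chloro in place of hydrogen on an aromatic carbon and moves the read-out hardly at all. Compound 3 `COc1ccc(-c2nn(-c3ccccc3)cc2C(=O)NOCc2ccccc2Cl)cc1` differs from compound 1 by methoxy in place of methyl on an aromatic carbon, para to a large group, so that the 4-methylphenyl becomes a 4-methoxyphenyl. Going by the values given here, no measured step bears directly on this exchange. Among the compounds with values here, the one step available, from compound 1 to compound 2, concerns a different part of the molecule and stayed within the scatter, so it offers no direction for the present change. Without a precedent, the expectation is a step of no size beyond the scatter, that is a 1.0-fold lower number from compound 1 to compound 3 (0.01 log units; within the scatter). Compound 3 is therefore estimated at 2600 nM in this assay, with a range from 1300 nM to 5200 nM.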

Compound 3, concentration for 50% growth inhibition: 3730 nM
The estimate for compound 3 lay 1.4-fold (0.16 log units) below the measured number; the range from low to high includes it.
By their numbers in this assay, from the lowest: compounds 2, 1 and 3 (each within the scatter of the next).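

In this assay, for the compounds shown here, the exchange of the 4-methylphenyl for the 4-methoxyphenyl gives a 1.4-fold higher number from compound 1 to compound 3 (0.15 log units; within the scatter), the first reading at this position, on which neither earlier compound bore. The position therefore takes methoxy in place of methyl, with one more heavy atom and one hydrogen-bond acceptor entering, without a step beyond the scatter, just as chloro in place of hydrogen elsewhere in the molecule gave only a 1.1-fold lower number from compound 1 to compound 2 (0.06 log units; within the scatter). No measurement at hand accounts for this result or tells what either group does at this position.

With only methyl and methoxy seen here, the compounds shown leave open whether a different group in this place, such as an amine, a carboxylic acid or a longer chain like butoxy, would move the number beyond the scatter. They also leave open whether methoxy in place of methyl would read the same way on compound 2, which carries the additional chloro.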